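A few compounds are considered here, and "the series" means these few. Any claim that something is new, unique, unknown or untested is made for them only; others in the source may bear on it.

In a physicochemical assay for solubility (on this read-out lower numbers stand for lower solubility and higher numbers for higher solubility), compound 1 `CC(C)(C)CC(=O)N1CCC[C@H]1C(=O)N1CCC(NS(=O)(=O)c2cc(S(=O)(=O)c3ccccc3)ccc2C(F)(F)F)CC1` gives 25000 nM and compound 2 `O=C([C@@H]1CCCN1C(=O)N1CCOCC1)N1CCC(NS(=O)(=O)c2cc(S(=O)(=O)c3ccccc3)ccc2C(F)(F)F)CC1` gives 50000 nM, so the two numbers sit within the scatter of each other. Compound 3 `O=C([C@@H]1CCCN1Cc1ccccc1)N1CCC(NS(=O)(=O)c2cc(S(=O)(=O)c3ccccc3)ccc2C(F)(F)F)CC1` has benzyl in place of (morpholin-4-yl)carbonyl on an amine nitrogen in a ring. Going by the values given here, only one measured step bears on this, and only loosely, since it swaps a group on a carbonyl carbon and removes nothing: a 2.0-fold higher number from compound 1 to compound 2 (0.30 log units; within the scatter). A modest move to a lower number is therefore expected, with little certainty about its direction. The estimated step is a 2.0-fold lower number from compound 2 to compound 3 (0.30 log units; within the scatter). For compound 3 the expected value is 25000 nM, within an estimated range of 8000 nM to 60000 nM.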

Compound 3, solubility: 25000 nM
Estimate against measurement, compound 3: no gap at the digits printed, and the stated range covers the measured number.
By their numbers in this assay, from the lowest: compounds 1, 3 and 2 (each within the scatter of the next).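

In this assay a benzyl group on the ring amine nitrogen, with no carbonyl, cannot be told apart from either earlier group: replacing (morpholin-4-yl)carbonyl gives a 2.0-fold lower number from compound 2 to compound 3 (0.30 log units; within the scatter) and replacing neopentylcarbonyl gives no change at the digits printed from compound 1 to compound 3 (within the scatter). At this position, then, the read-out does not separate an all-carbon aromatic ring from the two carbonyl-linked groups. No measured evidence accounts for this. Open, as far as these compounds go, is whether a carboxylic acid or a longer chain ending in an amine on this nitrogen would shift the number beyond the scatter.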